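Replacing the Carboxy Group on a Shared Core

The source may hold more compounds than are shown below. What is called first, only, known or untested is meant among the compounds shown, and "the series" means these compounds.

Values measured in a functional assay on cells (Platelet, Homo sapiens) for inhibition (on this read-out higher numbers stand for weaker inhibition and lower numbers for stronger inhibition), each one a limit of the assay:
Compound 1, `CCOC(=O)c1ccc(-c2nn(Cc3cccc(F)c3)c3ccccc23)cc1`: > 10000 nM
Compound 2, `CCOC(=O)c1ccc(-c2nn(Cc3cccnc3)c3ccccc23)cc1`: > 10000 nM
Compound 3, `O=C(O)c1ccc(-c2nn(Cc3ccccc3)c3ccccc23)cc1`: > 10000 nM

Compound 3 sits at the limit of this assay, and it is not alone there: all three measured compounds stand at the same limit (the limit of > 10000 nM in this assay, at which 3 of the 3 values shown sit). Among the compounds with values here, the single step between measured compounds, a step that the two limits leave unreadable from compound 1 to compound 2, swaps pyridin-3-yl for 3-fluorophenyl on a saturated chain carbon bound to an aromatic nitrogen, yet both of its ends are limits, so its size cannot be read. Compound 4, `CO/N=C\c1ccc(-c2nn(Cc3ccccc3)c3ccccc23)cc1`, differs from compound 3 by a group of 4 heavy atoms (2 carbon, 1 nitrogen, 1 oxygen; no ring) in place of a group of 3 heavy atoms (1 carbon, 2 oxygen; no ring), on an aromatic carbon. The change removes the carboxy group and brings in a group of 4 heavy atoms with 2 hydrogen-bond acceptors and no donor, on an aromatic carbon para to a large group. No measured step covers a change of this kind, and the one step shown is unreadable, so nothing in the numbers points to a direction or a size for the step in this assay. Compound 4 is therefore expected to give about 10000 nM, with a range from 3000 nM to 30000 nM. That estimate means an expected step of a number no higher from compound 3 to compound 4 (the limit leaves the size open), which is no more than the scatter.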

Compound 4, half-maximal inhibitory concentration: > 10000 nM
Compound 4: no number, only a limit; the forecaster's own chance of this, stated with the estimate: 60%; the middle value lies on the limit itself.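

In this assay compound 4 gives > 10000 nM, a limit of the assay. Within the data shown here, compound 3 also stands at a limit, so no step between compound 3 and compound 4 can be read. The compounds shown leave open which change on the shared core, if any, would give a measurable value, as every value stands at one limit: the limit of > 10000 nM in this assay, at which 4 of the 4 values shown sit.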